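The source may hold more compounds than are shown below. What is called first, only, known or untested is meant among the compounds shown, and "the series" means these compounds.

Among the compounds with values here, in a functional assay on HT-29 cells (Homo sapiens) (on this read-out higher numbers stand for weaker inhibition of growth and lower numbers for stronger inhibition of growth), two compounds have numbers so far. Within the data shown here, compound 1 (`O=S(=O)(/C=C/c1ccc(Cl)c(Cl)c1)Cc1ccc(Nc2ncnc3ccccc23)cc1`) gives 11000 nM and compound 2 (`CC(C)(C)c1cc(/C=C/S(=O)(=O)Cc2ccc(Nc3ncnc4ccccc34)cc2)cc(C(C)(C)C)c1O`) gives 17000 nM and these two values lie within the usual scatter of each other, so compound 1 stands level with its only measured neighbour. Compound 3 (`O=S(=O)(/C=C/c1ccc(F)cc1F)Cc1ccc(Nc2ncnc3ccccc23)cc1`) is still unmeasured. It carries 2,4-difluorophenyl in place of 3,4-dichlorophenyl on a double-bonded chain carbon bound to a double-bonded chain carbon. Among the measured compounds shown here, no measured pair isolates a change of this kind, so the only guide is how closely compound 1 sits to compound 2 at 17000 nM in the same read-out. The step expected in this assay is a 1.2-fold higher number from compound 1 to compound 3 (0.07 log units; within the scatter) and so no shift beyond the scatter in either direction. The estimated value for compound 3 is 13000 nM (expected range 5000 nM to 35000 nM).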

Compound 3, concentration for 50% growth inhibition: > 100000 nM
Compound 3: no number, only a limit (the forecaster's own chance of this, stated with the estimate: 8%); middle value at least 7.6-fold (0.88 log units) from the limit.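

In this assay, within the data shown here, replacing 3,4-dichlorophenyl with 2,4-difluorophenyl on a double-bonded chain carbon bound to a double-bonded chain carbon gives the only step here that can be read as beyond the scatter: an at least 9.0-fold higher number from compound 1 to compound 3 (0.95 log units; beyond the scatter). This position is therefore sensitive to the change, even though the group entering and the group leaving have the same count of heavy atoms and the same six-membered aromatic ring. For compound 3, > 100000 nM is a limit of the assay and not a number, so the full size of the step remains unknown: the limit of > 100000 nM in this assay, at which 1 of the 3 values shown sits.

This pair changes the halogen and its placement together, and the compounds shown do not separate the two. Going by these compounds, how 3,4-difluorophenyl, 2,4-dichlorophenyl or an aminophenyl group would read at this position remains open.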